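This account rests on a few compounds, and the source may have more. Where it says the series, first, only, none or still open, it means among the compounds named here.

Measured compounds in an ADME assay on HEK-293T cells (Homo sapiens) for cytotoxicity, with a stated time of 48 h; on this read-out higher numbers stand for lower toxicity in this test and lower numbers for higher toxicity in this test:

Compound 1, `CCc1ncnc(NCc2ccc(C(C)(C)C)cc2)c1Cl`. In this assay compound 1 gives > 10000 nM, which is a limit of the assay and not a number.
Compound 2, `CCc1ncnc(NC(CC)c2ccc(C(C)(C)C)cc2)c1Cl`. In this assay compound 2 gives > 10000 nM, again a limit.
Compound 3, `CCC(Nc1cc(C)ncn1)c1ccc(Oc2ccc(F)cc2)cc1`. In this assay compound 3 gives > 10000 nM, also a limit.

Among the measured compounds shown here, the one paired change among the measured compounds is ethyl in place of hydrogen on a saturated chain carbon bound to an aromatic carbon and a nitrogen on an aromatic ring. Its step in this assay, a step that the two limits leave unreadable from compound 1 to compound 2, cannot be sized, since both ends of the pair are limits. What the three values share is the limit of > 10000 nM in this assay, at which 3 of the 3 values shown sit; none of them gives a number to set a step against.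

Compound 4, `CCCc1cc(NC(CC)c2ccc(Oc3ccc(F)cc3)cc2)ncn1`, is the unmeasured analogue of compound 3. It differs from compound 3 by ethyl in place of hydrogen on a saturated chain carbon bound to an aromatic carbon. For the measured compounds named here, this is the same kind of change as the one from compound 1 to compound 2, not the same change: in the earlier pair the saturated chain carbon is bound to an aromatic carbon and a nitrogen on an aromatic ring, whereas here it is bound to an aromatic carbon only. The difference between the core of compound 3 and the core of compound 1 is not broken down here.

For this assay the step from compound 3 to compound 4 is expected to be a step that the limit leaves unreadable from compound 3 to compound 4, which rests on the limit of > 10000 nM in this assay, at which 3 of the 3 values shown sit, and on the unreadable a step that the two limits leave unreadable from compound 1 to compound 2; no measured value here points to toxicity appearing. Compound 4 is therefore estimated at 15000 nM, most likely reported again as a limit, with a range from 7000 nM to 40000 nM.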

Compound 4, half-maximal cytotoxic concentration: > 10000 nM
Compound 4 was reported as a limit (the forecaster's own chance of this, stated with the estimate: 85%); the middle value lies beyond the limit too.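

In this assay compound 4 gives > 10000 nM, which is a limit of the assay and not a number. Compound 3 also stands at a limit, so no step can be read between compound 3 and compound 4. Left open is how far any of the compounds lies from that limit, and whether any change shown alters cytotoxicity: the limit of > 10000 nM in this assay, at which 4 of the 4 values shown sit.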